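The source may report more compounds than this note shows. Statements on the series, on what has been measured and on what is new or still open speak of the compounds shown alone.

Compound 1 `O=S(=O)(Nc1ccc2oc(-c3ccccc3)nc2c1)c1cccc(C(F)(F)F)c1` in an assay on isolated protein for inhibition of malate dehydrogenase, mitochondrial (Sus scrofa), with stated times of 45 min and 30 min (on this read-out lower numbers stand for stronger inhibition and higher numbers for weaker inhibition), gives > 63000 nM.
Compound 2 `O=S(=O)(Nc1ccc2oc(-c3ccccc3)nc2c1)c1ccc(Cl)cc1` in this assay gives > 63000 nM.

Both of these values are limits of the assay and not numbers. Compound 2 stands at that limit, as does compound 1, matching (the limit of > 63000 nM in this assay, at which 2 of the 2 values shown sit). Compound 3 `O=S(=O)(Nc1ccc2oc(-c3ccccc3)nc2c1)c1cccc(O)c1` differs from compound 2 by 3-hydroxyphenyl in place of 4-chlorophenyl on a sulfonyl sulfur. Among the compounds with values here, no step between measured compounds is available here, so the expected step from compound 2 to compound 3 in this assay is a number no higher from compound 2 to compound 3 (the limit leaves the size open), which is expected to mean no change beyond the scatter. Compound 3 is therefore estimated at 63000 nM, within 20000 nM to 150000 nM, and is expected most likely to be reported again only as a limit.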

Compound 3, half-maximal inhibitory concentration: > 63000 nM
Compound 3 was reported as a limit (the forecaster's own chance of this, stated with the estimate: 70%); the middle value sits exactly at the limit.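

In this assay, within the data shown here, compound 3 gives > 63000 nM, a limit and not a number, so no step from compound 1 or compound 2 to compound 3 can be read. The compounds shown leave open how strongly each one inhibits, and whether 3-hydroxyphenyl and 4-chlorophenyl differ at all: the limit of > 63000 nM in this assay, at which 3 of the 3 values shown sit.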